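Extending the Chain from Compound 3 to Compound 4

The source may report more compounds than this note shows. Statements on the series, on what has been measured and on what is new or still open speak of the compounds shown alone.

- Compound 1 `C=C[C@@](C)(/C=C/c1ccc(OC(=O)CCCC)cc1)CCC=C(C)C`: 42%
- Compound 2 `C=C[C@@](C)(/C=C/c1ccc(OC(=O)CCCCC)cc1)CCC=C(C)C`: 28%
- Compound 3 `C=C[C@@](C)(/C=C/c1ccc(OC(=O)CCCCCCCCC)cc1)CCC=C(C)C`: 50%

These values come from a functional assay on PC-3 cells (Homo sapiens) for inhibition, with a stated time of 48 h, tested at 50 uM; on this read-out lower numbers stand for less inhibition of growth and higher numbers for more inhibition of growth at the one concentration tested. Compound 3 gives 50%, which places it clearly apart from only one of the other two: a number 22 percentage points higher from compound 2 to compound 3 (beyond the scatter), but a number 8 percentage points higher from compound 1 to compound 3 (within the scatter).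

Compound 4 `C=C[C@@](C)(/C=C/c1ccc(OC(=O)CCCCCCCCCCCCCCC)cc1)CCC=C(C)C` differs from compound 3 by hexyl in place of hydrogen on a saturated chain carbon, nine bonds along the chain from a carbonyl carbon. The chain steps measured so far give no single direction: a number 14 percentage points lower from compound 1 to compound 2 (beyond the scatter), then a number 22 percentage points higher from compound 2 to compound 3 (beyond the scatter). Since these modest steps run in opposite ways, no change beyond the scatter is expected in this assay. The estimated step is a number 8 percentage points lower from compound 3 to compound 4 (within the scatter). Compound 4 is expected at 42%, with an estimated range of 22% to 62%.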

Compound 4, percent growth inhibition at one concentration: 62%
For compound 4 the middle estimate is 20 percentage points below the measured one; measured number inside the range.
By their numbers in this assay, from the lowest: compound 2; then compounds 1 and 3 (each within the scatter of the next); then compound 4.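

In this assay, lengthening the chain by hexyl at this position now gives a step beyond the scatter, a number 12 percentage points higher from compound 3 to compound 4 (beyond the scatter), where the earlier move from compound 1 to compound 3 did not. Compound 4 also stands clear of both shorter chains, with a number 34 percentage points higher from compound 2 to compound 4 (beyond the scatter) and a number 20 percentage points higher from compound 1 to compound 4 (beyond the scatter), so the longest chain shown gives the highest number, although compound 2 goes against a steady rise with length. Nothing measured here explains this difference.

Going by these compounds, whether a longer chain would raise the number further remains open. So does the effect of a carboxylic acid or an amine at the chain end.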